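The source may hold more compounds than are shown below. What is called first, only, known or untested is meant among the compounds shown, and "the series" means these compounds.

Measured so far:
Compound 1, `NC(=O)c1cn(Cc2nnc(-c3cc(S(N)(=O)=O)c(SCc4ccccc4)cc3Cl)o2)nn1`: 78000 nM
Compound 2, `NCc1nnc(-c2cc(S(N)(=O)=O)c(SCc3ccccc3)cc2Cl)o1`: 135000 nM

These two values come from a functional assay on MCF7 cells (Homo sapiens) for cytotoxicity, read by MTT assay, with a stated time of 72 h; a lower number here means a stronger inhibitor, a higher number a weaker inhibitor. Compound 2 has the highest of the two numbers, but its nearest neighbour, compound 1, lies within the usual scatter of it: a 1.7-fold higher number from compound 1 to compound 2 (0.24 log units; within the scatter). So the two cannot be ordered with confidence.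

Compound 3, `NS(=O)(=O)c1cc(-c2nnc(CNC(=O)c3ccccc3)o2)c(Cl)cc1SCc1ccccc1`, keeps the whole of compound 2 and differs in one place: benzoyl in place of hydrogen on an amine nitrogen. Among the measured compounds shown here, no measured step matches this exactly. For the measured compounds named here, the only step that bears on it is the one from compound 1 to compound 2, where a larger group on the same chain carbon was replaced by the bare amine, and that step stayed within the scatter. On that basis compound 3, which again carries a larger group at this position, is expected to show a step of about a 1.5-fold lower number from compound 2 to compound 3 (0.18 log units; within the scatter) in this assay, that is no change beyond the scatter. The estimate for compound 3 is 90000 nM, with a range from 30000 nM to 270000 nM.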

Compound 3, half-maximal inhibitory concentration: 66000 nM
The estimate for compound 3 lay 1.4-fold (0.13 log units) above the measured number, within the range that was stated.
By their numbers in this assay, from the lowest: compounds 3, 1 and 2 (each within the scatter of the next, the first and the last beyond it).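

In this assay, among the compounds shown here, benzoyl on the amine nitrogen gives the first step at this position that goes beyond the scatter, though only modestly (a 2.0-fold lower number from compound 2 to compound 3 (0.31 log units; beyond the scatter)). The benzamido group and the 4-carbamoyl-1H-1,2,3-triazol-1-yl group on the same saturated chain carbon cannot be told apart (a 1.2-fold lower number from compound 1 to compound 3 (0.07 log units; within the scatter)), so two different large groups read alike here, and only compound 2, with its bare amino group, sits apart from one of them. Nothing measured here explains the step from the amine to the amide.

From the compounds shown here alone, it remains open whether the benzene ring of the benzoyl group or its carbonyl goes with this step. An acetyl group on the same amine nitrogen, which keeps the carbonyl without the ring, and a benzyl group, which keeps the ring without the carbonyl, would separate the two.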